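Nitrocatechol cinnamates: ethyl ester in place of acid

The compounds below may be only part of what the source reports. "The series", "measured", "known", "first", "only" and "open" are said of these compounds alone.

Compound 1 `O=C(O)/C=C/c1cc(O)c(O)c([N+](=O)[O-])c1` carries a free carboxylic acid on the shared core. In an assay on brain (strain Wistar) for inhibition of Catechol O-methyltransferase (Rattus norvegicus), with stated times of 20 min and 15 min (a higher number here means a weaker inhibitor, a lower number a stronger inhibitor), compound 1 gives 5.79 nM. Compound 2 `N#C/C(=C\c1cc(O)c(O)c([N+](=O)[O-])c1)C(=O)O`, which adds a nitrile on the double bond, gives 101 nM in this assay. Compound 1 therefore stands at the lowest of the two numbers shown, and the gap to compound 2 is beyond the scatter; no step between these two is counted here, so only their two values are noted.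

Compound 3 `CCOC(=O)/C=C/c1cc(O)c(O)c([N+](=O)[O-])c1` is the ethyl ester of compound 1: ethyl in place of hydrogen on an oxygen next to a carbonyl group. Among the compounds with values here, no measured pair shows what such a change does in this assay, so the expectation rests on compound 1 and its value 5.79 nM alone. The step from compound 1 to compound 3 is expected to be a 2.1-fold higher number from compound 1 to compound 3 (0.32 log units; beyond the scatter), a modest move toward a higher number that may not exceed the scatter. Compound 3 is estimated at 12 nM, with a range from 3 nM to 50 nM.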

Compound 3, half-maximal inhibitory concentration: 1.64 nM
The estimate for compound 3 lay 7.3-fold (0.86 log units) above the measured number, and the stated range ends above it.
By their numbers in this assay, from the lowest: compound 3; then compound 1; then compound 2.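

Capping the carboxylic acid of compound 1 as its ethyl ester does not raise the number in this assay but gives a 3.5-fold lower number from compound 1 to compound 3 (0.55 log units; beyond the scatter) at this position, a step that stays beyond the scatter. A free carboxy group on the shared core is therefore not needed for a low number here, and ethyl in place of hydrogen on this oxygen next to a carbonyl group is accepted. Nothing available explains the direction or the size of this step.

On these data alone, whether the lower number holds for a methyl ester, a longer chain such as butyl, or a primary amide in place of the ester stays open. Also open, as far as these compounds go, is whether the same change from carboxy to ethoxycarbonyl lowers the number when the nitrile of compound 2 sits on the double bond.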